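Urea aryl swap on the shared core, toxicity expectation

The compounds below may be only part of what the source reports. "The series", "measured", "known", "first", "only" and "open" are said of these compounds alone.

Compound 1 `O=C(Nc1cccc(-n2cc(-c3ccncc3)c(-c3ccc(Cl)c(O)c3)n2)c1)Nc1ccc(Cl)c(Cl)c1` carries a 3,4-dichlorophenyl on the urea nitrogen. In a functional assay on A549 cells (Homo sapiens) for inhibition, read by sulforhodamine B assay, with a stated time of 48 h (on this read-out higher numbers stand for lower toxicity in this test and lower numbers for higher toxicity in this test), compound 1 gives only a limit, > 32500 nM. Compound 2 `COc1cc(-c2nn(-c3cccc(NC(=O)c4ccc(Cl)c(C(F)(F)F)c4)c3)cc2-c2ccncc2)ccc1Cl` likewise gives a limit in this assay, > 32500 nM. Compound 3 `COc1cc(-c2nn(-c3cccc(NC(=O)c4ccccc4)c3)cc2-c2ccncc2)ccc1Cl` also returns a limit in this assay, > 100000 nM. Going by the values given here, the only single-point pair among the measured compounds, the change of phenyl in place of 4-chloro-3-(trifluoromethyl)phenyl on a carbonyl carbon, is a step that the two limits leave unreadable from compound 2 to compound 3. Compound 1 therefore stands at a limit, as do both other values shown, and the evidence of this assay consists of the limit of > 100000 nM in this assay, at which 1 of the 3 values shown sits, and the limit of > 32500 nM in this assay, at which 2 of the 3 values shown sit, alone.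

Compound 4 `O=C(Nc1cccc(-n2cc(-c3ccncc3)c(-c3ccc(Cl)c(O)c3)n2)c1)Nc1cccc(C(F)(F)F)c1` differs from compound 1 by 3-(trifluoromethyl)phenyl in place of 3,4-dichlorophenyl on an amide-type nitrogen. Among the compounds with values here, no measured step bears on this change, and the one step that exists cannot be read in size. Nothing in the series indicates toxicity reaching a measurable number, so the expectation is that compound 4 again sits at or beyond a limit, with no readable step in this assay, which is an estimated step that the limit leaves unreadable from compound 1 to compound 4. The estimate for compound 4 in this assay is 60000 nM, within an expected range from 20000 nM to 200000 nM.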

Compound 4, concentration lethal to 50% of the cells: > 32500 nM
Compound 4: no number, only a limit (the forecaster's own chance of this, stated with the estimate: 80%); the middle value is on the limit's open side.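

Compound 1 and compound 4 each give only a limit in this assay, and the step between them, 3-(trifluoromethyl)phenyl in place of 3,4-dichlorophenyl on an amide-type nitrogen, cannot be read. The compounds shown leave open at what concentration any of them reaches half-maximal cell kill, and whether any change of group on the shared core alters toxicity in this assay.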